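The compounds below may be only part of what the source reports. "The series", "measured", "known", "first", "only" and "open" are said of these compounds alone.

Compound 3 `CCOc1cc(NC(=O)NCc2cc(C)c(-c3cn(C)nc3C(F)(F)F)nn2)cc(C#N)n1` is known in an ADME assay on microsomes from liver (Homo sapiens) for metabolic stability, read by LC-MS, with a stated time of 4 h, tested at 1 uM (on this read-out higher numbers stand for fast clearance and lower numbers for slow clearance), only as a limit, < 28.4 mL/min/kg, the point named in the limit of < 28.4 mL/min/kg in this assay, at which 1 of the 3 values shown sits. Compound 2 `Cc1cc(CNC(=O)Nc2cc(Cl)nc(OCC(F)F)c2)nnc1-c1cn(C)nc1C(F)(F)F` likewise reaches only a limit in this assay, < 50 mL/min/kg. Among the compounds with values here, compound 1 `CCOc1cc(NC(=O)NCc2cc(C)c(-c3cn(C)nc3C(F)(F)F)cn2)cc(Cl)n1` gives 150 mL/min/kg in this assay, the one number among the three that is not a limit. Compound 4 `CCOc1cc(NC(=O)NCc2cc(C)c(-c3cn(C)nc3C(F)(F)F)nn2)cc(C)n1` has not yet been measured; it differs from compound 3 by methyl in place of cyano on an aromatic carbon. Within the data shown here, no measured pair shows this single change, so the expectation rests on the spread among compounds 1, 2 and 3. The step from compound 3 to compound 4 is expected to be an at least 2.1-fold higher number from compound 3 to compound 4 (0.32 log units; beyond the scatter), toward faster clearance. Compound 4 is expected to give 60 mL/min/kg, within a range from 25 mL/min/kg to 150 mL/min/kg.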

Compound 4, clearance: < 15 mL/min/kg
Compound 4 gave a limit, no number; the forecaster's own chance of this, stated with the estimate: 20%; middle value at least 4.0-fold (0.60 log units) away from the limit.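

Compound 3 and compound 4 are each known only as a limit in this assay, and the step between them cannot be read. The compounds shown leave open whether methyl in place of cyano raises or lowers clearance, and by how much.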